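Compound 3 to Compound 4: Cytotoxicity Estimate

The source may hold more compounds than are shown below. What is called first, only, known or untested is meant among the compounds shown, and "the series" means these compounds.

Compound 1 `C=CCOc1cc(OC)c(C(=O)/C=C/c2ccc(F)cc2)c(OCC=C)c1`: 13800 nM
Compound 2 `COc1cc(O)cc(O)c1C(=O)/C=C/c1ccc(Cl)cc1`: 19000 nM
Compound 3 `C=CCOc1cc(OC)c(C(=O)/C=C/Cc2ccccc2)c(OCC=C)c1`: 14800 nM

All three were measured in a toxicity assay on cells (Macrophage, Mus musculus, strain BALB/c) for cytotoxicity, read by MTT assay; a higher number here means a weaker inhibitor, a lower number a stronger inhibitor. Compound 3 gives the second highest of the three numbers, yet compound 1 and compound 2 both lie within the scatter of it, so the three cannot be told apart. Compound 4 `C=CCOc1cc(OC)c(C(=O)/C=C/c2ccc([N+](=O)[O-])cc2)c(OCC=C)c1` is not yet measured. It differs from compound 3 in one place: 4-nitrophenyl in place of benzyl on a double-bonded chain carbon bound to a double-bonded chain carbon. Within the data shown here, one measured step bears on this change, since it swaps the group at the same place: a 1.1-fold higher number from compound 1 to compound 3 (0.03 log units; within the scatter). That exchange left the number unchanged within the scatter, so the expected step is a 1.0-fold lower number from compound 3 to compound 4 (0.01 log units; within the scatter), no change beyond the scatter. Compound 4 is therefore estimated at 14500 nM, in a range from 7000 nM to 30000 nM.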

Compound 4, half-maximal inhibitory concentration: 13200 nM
For compound 4 the middle estimate is 1.1-fold (0.04 log units) above the measured one; the range from low to high includes it.
By their numbers in this assay, from the lowest: compounds 4, 1, 3 and 2 (each within the scatter of the next).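

Swapping benzyl for 4-nitrophenyl on this double-bonded chain carbon does not move the result in this assay (a 1.1-fold lower number from compound 3 to compound 4 (0.05 log units; within the scatter)). Nitro in place of fluoro on an aromatic carbon does not move it either (a 1.0-fold lower number from compound 1 to compound 4 (0.02 log units; within the scatter)). This place has therefore now held benzyl, 4-fluorophenyl and 4-nitrophenyl with no change beyond the scatter, and nothing available explains this flat result.

Still open, going by these compounds, is whether an amine or a carboxylic acid in place of the nitro group would shift the number. The same holds for a longer chain in place of benzyl.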